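This account rests on a few compounds, and the source may have more. Where it says the series, first, only, none or still open, it means among the compounds named here.

Measured compounds in a functional assay on A549 cells (Homo sapiens) for inhibition, read by MTT assay, with a stated time of 72 h; on this read-out lower numbers stand for stronger inhibition and higher numbers for weaker inhibition:
compound 1, `COc1cc2c(Oc3ccc(NC(=O)c4nn(-c5ccccc5)c(=O)cc4C)cc3F)ccnc2cc1OCCCN1CCN(C)CC1`, gives 350 nM;
compound 2, `COc1cc2c(Oc3ccc(NC(=O)c4nn(-c5ccccc5C(F)(F)F)c(=O)cc4C)cc3F)ccnc2cc1OCCCN1CCN(C)CC1`, gives 170 nM;
compound 3, `COc1ccc(-n2nc(C(=O)Nc3ccc(Oc4ccnc5cc(OCCCN6CCC(C)CC6)c(OC)cc45)c(F)c3)c(C)cc2=O)cc1`, gives 1100 nM.

Compound 3 stands at the highest of the three numbers in this assay, beyond the scatter from both compound 1 and compound 2, which lie at lower numbers.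

Compound 4, `COc1ccc(-n2nc(C(=O)Nc3ccc(Oc4ccnc5cc(OCCCN6CCN(C)CC6)c(OC)cc45)c(F)c3)c(C)cc2=O)cc1`, differs from compound 3 by 4-methylpiperazin-1-yl in place of 4-methylpiperidin-1-yl on a saturated chain carbon, three bonds along the chain from an oxygen on an aromatic ring. For the measured compounds named here, the only measured step, a 2.1-fold lower number from compound 1 to compound 2 (0.31 log units; beyond the scatter), concerns a trifluoromethyl on an aromatic ring and does not bear on this exchange. Going by the values given here, compounds 1 and 2 carry the 4-methylpiperazin-1-yl group that enters in compound 4, yet each differs from compound 3 at a second site as well, so their values show only that this group sits in compounds with lower numbers and cannot be weighed as a step. Among the compounds with values here, no measured step tests the exchange itself; the expected step in this assay is therefore none beyond the scatter, with a lean toward a lower number.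

Compound 4 is estimated at 700 nM in this assay, with a range from 250 nM to 2000 nM. This estimate amounts to an expected step of a 1.6-fold lower number from compound 3 to compound 4 (0.20 log units; within the scatter).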

Compound 4, half-maximal inhibitory concentration: 2200 nM
Estimate against measurement, compound 4: 3.1-fold (0.50 log units) below; the whole stated range lies below it.
By their numbers in this assay, from the lowest: compound 2; then compound 1; then compounds 3 and 4 (each within the scatter of the next).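

In this assay, 4-methylpiperazin-1-yl in place of 4-methylpiperidin-1-yl on a saturated chain carbon, three bonds along the chain from an oxygen on an aromatic ring, gives a 2.0-fold higher number from compound 3 to compound 4 (0.30 log units; within the scatter) and so is not separated from the usual scatter in this one pair. For the compounds shown here, the steps beyond the scatter now lie on the aromatic group instead: methoxy in place of hydrogen on an aromatic carbon gives a 6.3-fold higher number from compound 1 to compound 4 (0.80 log units; beyond the scatter) and 4-methoxyphenyl in place of 2-(trifluoromethyl)phenyl on an aromatic nitrogen gives a 13-fold higher number from compound 2 to compound 4 (1.11 log units; beyond the scatter) and, where the earlier compounds offered only trifluoromethyl at this group, methoxy goes with a higher number. No other measurement accompanies these values to account for any of these steps.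

Going by these compounds alone, whether the chain position tolerates other ends, such as a morpholin-4-yl group or a shorter chain, stays open, as compound 3 and compound 4 form the only pair that tests this place. Also open, going by these compounds, is how other groups on that phenyl, such as chlorine or a nitrile, would read, and whether the chain exchange would read the same with compound 1 or compound 2 as the starting point.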